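Title: Removing one methyl from the quaternary acid of compound 3

The source may hold more compounds than are shown below. What is called first, only, known or untested is meant among the compounds shown, and "the series" means these compounds.

Compounds measured so far:
compound 1 `C[C@@H](C(=O)O)c1nn(Cc2cn3cc(OCC4CC4)c(Cl)cc3n2)c2ccccc2c1=O` — 2.41
compound 2 `O=C(O)Cc1nn(Cc2cn3cc(OCC4CC4)c(Cl)cc3n2)c2ccccc2c1=O` — 2.13
compound 3 `CC(C)(C(=O)O)c1nn(Cc2cn3cc(OCC4CC4)c(Cl)cc3n2)c2ccccc2c1=O` — 2.95

In a physicochemical assay for lipophilicity, at pH 7.4 (on this read-out higher numbers stand for higher lipophilicity and lower numbers for lower lipophilicity), compound 3 stands highest of the three, with compound 1 nearest and compound 2 furthest. Compound 4 `C[C@H](C(=O)O)c1nn(Cc2cn3cc(OCC4CC4)c(Cl)cc3n2)c2ccccc2c1=O` has not yet been measured. Relative to compound 3 the change is 1-carboxyethyl in place of 1-carboxy-1-methylethyl on an aromatic carbon. Compound 4 therefore carries the same 1-carboxyethyl group as compound 1, drawn with the opposite configuration at its single stereocentre, while compounds 2 and 3 differ from it in the group itself. The step that bears most directly on the change is a number 0.54 log units higher from compound 1 to compound 3 (beyond the scatter), and the change from compound 3 to compound 4 runs that step backwards; the larger step of a number 0.82 log units higher from compound 2 to compound 3 (beyond the scatter) shows the same direction for the loss of two methyls. A fall of modest size in this assay is therefore expected, estimated as a number 0.54 log units lower from compound 3 to compound 4 (beyond the scatter). Compound 4 is expected to give about 2.41 in this assay, most likely between 2.15 and 2.7.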

Compound 4, distribution coefficient: 2.39
Estimate against measurement, compound 4: 0.02 log units above, and the stated range covers the measured number.
By their numbers in this assay, from the lowest: compounds 2, 4 and 1 (each within the scatter of the next); then compound 3.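

In this assay the two drawn configurations of the 1-carboxyethyl group cannot be told apart, with a number 0.02 log units lower from compound 1 to compound 4 (within the scatter), and this comparison isolates the stereocentre alone: the fact that compounds 1 and 4 differ only in the configuration as drawn

In this configuration too, going from 1-carboxy-1-methylethyl to 1-carboxyethyl gives a step beyond the scatter, a number 0.56 log units lower from compound 3 to compound 4 (beyond the scatter). Adding one methyl to carboxymethyl stays within the scatter, a number 0.26 log units higher from compound 2 to compound 4 (within the scatter), as it does with the opposite configuration, so among these compounds only the second methyl, in compound 3, moves the number beyond the scatter.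

The compounds shown leave open how this assay would respond to an ethyl group on that chain carbon, or to a primary amide in place of the carboxylic acid. They also leave open whether the two configurations would match in any other read-out.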